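The compounds below may be only part of what the source reports. "The series", "measured", "known", "first", "only" and "open" are said of these compounds alone.

Compound 1 `C=C1C[C@]23C[C@@]1(O)CC[C@@H]2c1cccc(C)c1[C@@H]3Cn1cc(-c2ccccc2)nn1` and compound 2 `C=C1C[C@]23C[C@@]1(O)CC[C@@H]2c1cccc(C)c1[C@@H]3Cn1cc(-c2ccc(C(F)(F)F)cc2)nn1` share one core, while compound 3 `C=C1C[C@]23C[C@@]1(O)CC[C@H]2c1ccc(OS(=O)(=O)c2ccc(C)cc2)c(C)c1[C@@H]3Cn1cc(-c2ccccc2)nn1` and compound 4 `C=C1C[C@]23C[C@@]1(O)CC[C@H]2c1ccc(OS(=O)(=O)c2ccc(C)cc2)c(C)c1[C@@H]3Cn1cc(-c2ccc(C(F)(F)F)cc2)nn1` share another; how the two cores differ is not broken down here. In a functional assay on SMMC-7721 cells (Homo sapiens) for cytotoxicity, read by MTT assay, with a stated time of 4 days (on this read-out higher numbers stand for weaker inhibition and lower numbers for stronger inhibition), compound 1 gives > 20000 nM, which is a limit of the assay and not a number. In this assay compound 2 gives > 20000 nM, again a limit. The change trifluoromethyl in place of hydrogen on an aromatic carbon therefore makes a step that the two limits leave unreadable from compound 1 to compound 2. In this assay compound 3 gives > 20000 nM, also a limit. Compound 4 carries the same change, (trifluoromethyl in place of hydrogen on an aromatic carbon), placed on the core of compound 3; the surroundings of the place are the same in both pairs, so it is the same change. All values shown so far sit at the limit of > 20000 nM in this assay, at which 3 of the 3 values shown sit, and nothing in the data separates any compound from another. For compound 4, the step that the limit leaves unreadable from compound 3 to compound 4 is expected, resting on a step that the two limits leave unreadable from compound 1 to compound 2 and on (the limit of > 20000 nM in this assay, at which 3 of the 3 values shown sit). The value expected for compound 4 is 30000 nM, with a likely range from 15000 nM to 80000 nM, and most probably the assay will report only a limit again.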

Compound 4, half-maximal inhibitory concentration: > 20000 nM
Compound 4: no number, only a limit; the forecaster's own chance of this, stated with the estimate: 85%; the middle value is on the limit's open side.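

In this assay no step can be read between compound 3 and compound 4, and compound 4 adds no readable step to the series, because both values are limits and not numbers: the limit of > 20000 nM in this assay, at which 4 of the 4 values shown sit.

The compounds shown leave open how far any of them lies from that limit, and whether the trifluoromethyl change or the difference between the two cores alters the read-out in this assay at all.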